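This account rests on a few compounds, and the source may have more. Where it says the series, first, only, none or still open, it means among the compounds named here.

Measured so far in an ADME assay on NIH3T3 cells (Mus musculus) for cytotoxicity, read by MTT assay, with a stated time of 24 h; a higher number here means a weaker inhibitor, a lower number a stronger inhibitor:
compound 1 `Cc1nnc(SCC(=O)N/N=c2/scc(-c3ccccc3)n2-c2ccccc2)s1` gives 197 ug/mL
compound 2 `Cc1nnc(SCC(=O)N/N=c2/scc(-c3ccc(F)cc3)n2-c2ccccc2)s1` gives 383 ug/mL
compound 3 `Cn1cnnc1SCC(=O)N/N=c1/scc(-c2ccc(F)cc2)n1-c1ccccc1` gives 65 ug/mL

Compound 2 and compound 1 differ by hydrogen in place of fluoro on an aromatic carbon; this gave a 1.9-fold lower number from compound 2 to compound 1 (0.29 log units; within the scatter). Compound 2 and compound 3 differ in the core, by 4-methyl-4H-1,2,4-triazol-3-yl in place of 5-methyl-1,3,4-thiadiazol-2-yl on a sulfur; this gave a 5.9-fold lower number from compound 2 to compound 3 (0.77 log units; beyond the scatter). Compound 3 has the lowest number of the three, its steps to compound 1 and compound 2 both beyond the scatter.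

Compound 4 `Cn1cnnc1SCC(=O)N/N=c1/scc(-c2ccccc2)n1-c1ccccc1` is not yet measured. It differs from compound 3 by hydrogen in place of fluoro on an aromatic carbon, the same change that separates compound 2 from compound 1, at the same kind of place; it occurs twice among these compounds. Compound 4 carries the core of compound 3 with the phenyl of compound 1.

In this assay, within the data shown here, a step of about the size seen from compound 2 to compound 1 is expected from compound 3 to compound 4, a 1.4-fold lower number from compound 3 to compound 4 (0.16 log units; within the scatter), because a 1.9-fold lower number from compound 2 to compound 1 (0.29 log units; within the scatter) is the only precedent for this change here, and it lay within the scatter. For compound 4 the expected value is 45 ug/mL, between 20 ug/mL and 100 ug/mL.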

Compound 4, half-maximal inhibitory concentration: 217 ug/mL
Beside the measured number, compound 4's estimate is 4.8-fold (0.68 log units) below it; the whole stated range lies below it.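

In this assay, hydrogen in place of fluoro on the 4-methyl-4H-1,2,4-triazol-3-yl series gave a 3.3-fold higher number from compound 3 to compound 4 (0.52 log units; beyond the scatter), so the change does not carry from one core to the other here: the same change on two cores in this assay, a 1.9-fold lower number (0.29 log units; within the scatter) from compound 2 to compound 1 and a 3.3-fold higher number (0.52 log units; beyond the scatter) from compound 3 to compound 4, 6.5-fold (0.81 log units) apart, beyond the scatter of two such steps With phenyl in place of 4-fluorophenyl, the swap from 5-methyl-1,3,4-thiadiazol-2-yl to 4-methyl-4H-1,2,4-triazol-3-yl gave a 1.1-fold higher number from compound 1 to compound 4 (0.04 log units; within the scatter), so the two changes do not add up across these compounds: the same change on two cores in this assay, a 5.9-fold lower number (0.77 log units; beyond the scatter) from compound 2 to compound 3 and a 1.1-fold higher number (0.04 log units; within the scatter) from compound 1 to compound 4, 6.5-fold (0.81 log units) apart, beyond the scatter of two such steps Both comparisons rest on the same four compounds and are therefore one observation, which a single value, that of compound 3 at 65 ug/mL, is enough to produce; they show that the step depends on its partner group here, but not the cause or whether this holds beyond these compounds.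

The compounds shown leave open whether chloro or methoxy in place of the fluoro would follow compound 3 or compound 2. They also leave open how an unmethylated triazole on the sulfur would behave with either aryl group.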